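Unsaturated Ureas of the Shared Chain: Compound 3 to Compound 4

The source may hold more compounds than are shown below. What is called first, only, known or untested is meant among the compounds shown, and "the series" means these compounds.

Compound 3 `CCCCCCCC/C=C\CCCCCCCCNC(=O)Nc1c(C)cc(C)cc1C` is a urea carrying a long unsaturated chain on one nitrogen and a trimethylphenyl group on the other. In an assay on microsomes from intestinal mucosa for inhibition of acyl-CoA:cholesterol acyltransferase (Oryctolagus cuniculus) (a lower number here means a stronger inhibitor, a higher number a weaker inhibitor), compound 3 gives 2900 nM, the highest of the two numbers available. Compound 1 `CCCCCCCC/C=C/CCCCCCCC(=O)Nc1c(OC)cc(OC)cc1OC`, an amide rather than a urea, gives 44 nM in this assay, a far lower number, and the gap lies well beyond the scatter. Compound 2 `CCCCCCCCCCCCCCCCCCSc1c(C)cccc1C` reaches only the limit of this assay, > 10000 nM; the limit of > 10000 nM in this assay, at which 1 of the 3 values shown sits, marks that point. Compound 4 `CCCCCCCC/C=C\CCCCCCCCNC(=O)Nc1ccc(F)cc1F` has not yet been measured. It differs from compound 3 by 2,4-difluorophenyl in place of 2,4,6-trimethylphenyl on an amide-type nitrogen. Within the data shown here, no measured pair shows this change. Compound 4 is expected to give 8000 nM, between 2000 nM and 30000 nM, which means an expected step of a 2.8-fold higher number from compound 3 to compound 4 (0.44 log units; beyond the scatter) toward a weaker inhibitor, possibly ending at the limit of this assay.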

Compound 4, half-maximal inhibitory concentration: 4700 nM
Compound 4: middle estimate off by 1.7-fold (0.23 log units), on the high side; the measured number falls inside the stated range.
By their numbers in this assay, from the lowest: compound 1; then compounds 3 and 4 (each within the scatter of the next). At a limit, above all of these: compound 2.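

On this amide-type nitrogen the step reads a 1.6-fold higher number from compound 3 to compound 4 (0.21 log units; within the scatter), so in this assay 2,4-difluorophenyl and 2,4,6-trimethylphenyl cannot be told apart. Among these compounds, this is the first direct comparison at this position, and it shows that a ring bearing fluorine and a ring bearing methyl groups can be exchanged here without a difference beyond the scatter. Nothing measured here explains this result.

The compounds shown leave open how an unsubstituted phenyl, a pyridine ring or a ring bearing a carboxylic acid would behave on this nitrogen.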